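This account rests on a few compounds, and the source may have more. Where it says the series, first, only, none or still open, it means among the compounds named here.

Three compounds share one core. For compound 1 `Oc1ccc(-c2cc(-c3ccccn3)nc(-c3ccccc3Cl)c2)cc1` the result in a functional assay on DU-145 cells (Homo sapiens) for cytotoxicity, read by CCK-8 assay and cell counting, with a stated time of 2 days (a higher number here means a weaker inhibitor, a lower number a stronger inhibitor), is "not determined" (no result reported). Compound 2 `Oc1ccc(-c2cc(-c3cccs3)nc(-c3ccccc3Cl)c2)cc1` gives 4190 nM in this assay, and compound 3 `Oc1ccc(-c2cc(-c3cccc(Cl)c3)nc(-c3cccs3)c2)cc1` gives 5740 nM. On these two numbers compound 2 gives the lower one, but the difference a 1.4-fold higher number from compound 2 to compound 3 (0.14 log units; within the scatter) is small, so the two cannot be told apart here.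

Compound 4 `Oc1cccc(-c2cc(-c3cccs3)nc(-c3ccccc3Cl)c2)c1` has not yet been measured. Compared with compound 2 the change is 3-hydroxyphenyl in place of 4-hydroxyphenyl on an aromatic carbon: the hydroxyl is moved around its ring while everything else stays the same. For the measured compounds named here, no measured pair shows exactly this move. Going by the values given here, the only related step, from compound 2 to compound 3, moves a chlorine around a different ring and gives a 1.4-fold higher number from compound 2 to compound 3 (0.14 log units; within the scatter), which stays within the scatter. On that single hint, a step of similar size, or none beyond the scatter, is expected in this assay. The estimated step of a 1.1-fold higher number from compound 2 to compound 4 (0.03 log units; within the scatter) therefore stays close to the starting point. Compound 4 is expected to give about 4500 nM, within a range from 1500 nM to 13000 nM.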

Compound 4, half-maximal inhibitory concentration: 1700 nM
For compound 4 the middle estimate is 2.6-fold (0.42 log units) above the measured one; measured number inside the range.
By their numbers in this assay, from the lowest: compound 4; then compounds 2 and 3 (each within the scatter of the next).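

Moving the hydroxyl around the ring that sits opposite the ring nitrogen, with 3-hydroxyphenyl in place of 4-hydroxyphenyl, gives a 2.5-fold lower number from compound 2 to compound 4 (0.39 log units; beyond the scatter) in this assay. This modest step shows that the number at this position depends on where the hydroxyl stands on its ring, even though the two groups have the same atoms; the earlier chlorine move, a 1.4-fold higher number from compound 2 to compound 3 (0.14 log units; within the scatter), showed no change beyond the scatter. No measurement here explains why the hydroxyl's location matters, so the reason remains unknown.

The compounds shown leave open whether the hydroxyl itself is needed, or whether an amine or a carboxylic acid at the same place would give a similar number. They also leave open whether 3-hydroxyphenyl would give a similar step with other groups on the shared core.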